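Adding Bromine to the Strongest of Three Inhibitors

The compounds below may be only part of what the source reports. "The series", "measured", "known", "first", "only" and "open" are said of these compounds alone.

Measured in a functional assay on A549 cells (Homo sapiens) for inhibition, read by MTT assay, with a stated time of 72 h; on this read-out lower numbers stand for stronger inhibition and higher numbers for weaker inhibition:
- compound 1 `Cn1ccc2c(Oc3ccc(NC(=O)c4cn(-c5ccccc5)c5ccccc5c4=O)cc3F)ccnc21` gives 1720 nM
- compound 2 `Cn1ccc2c(Oc3ccc(NC(=O)c4cn(-c5ccc(Br)cc5)c5ccccc5c4=O)cc3F)ccnc21` gives 1390 nM
- compound 3 `O=C(Nc1ccc(Oc2ccnc3[nH]ccc23)c(F)c1)c1cn(-c2ccccc2)c2ccccc2c1=O` gives 420 nM

Compound 3 stands lowest of the three in this assay, beyond the scatter from both others: the step of a 4.1-fold lower number from compound 1 to compound 3 (0.61 log units; beyond the scatter) shows what removing the methyl from the aromatic nitrogen did. Compound 4 `O=C(Nc1ccc(Oc2ccnc3[nH]ccc23)c(F)c1)c1cn(-c2ccc(Br)cc2)c2ccccc2c1=O` differs from compound 3 by bromo in place of hydrogen on an aromatic carbon. Among the measured compounds shown here, the one measured step of the same kind, a 1.2-fold lower number from compound 1 to compound 2 (0.09 log units; within the scatter), stayed within the scatter. The same small change is therefore expected for compound 4, with a 1.2-fold lower number from compound 3 to compound 4 (0.07 log units; within the scatter) as the estimated step, and no shift beyond the scatter. Compound 4 is thus expected to give about 360 nM in this assay, within a range of 180 nM to 800 nM.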

Compound 4, half-maximal inhibitory concentration: 950 nM
Compound 4: the middle estimate sits 2.6-fold (0.42 log units) below what was measured; the whole stated range lies below it.
By their numbers in this assay, from the lowest: compound 3; then compounds 4, 2 and 1 (each within the scatter of the next).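

The change from phenyl to 4-bromophenyl proves not to be neutral on every core: on the core without the methyl it gives a 2.3-fold higher number from compound 3 to compound 4 (0.35 log units; beyond the scatter). Its effect therefore depends on the rest of the molecule: the same change on two cores in this assay, a 1.2-fold lower number (0.09 log units; within the scatter) from compound 1 to compound 2 and a 2.3-fold higher number (0.35 log units; beyond the scatter) from compound 3 to compound 4, 2.8-fold (0.45 log units) apart, beyond the scatter of two such steps

The reverse also holds, since removing the methyl from the aromatic nitrogen gives a gain beyond the scatter only without the bromo, and with it just a 1.5-fold lower number from compound 2 to compound 4 (0.17 log units; within the scatter): the same change on two cores in this assay, a 4.1-fold lower number (0.61 log units; beyond the scatter) from compound 1 to compound 3 and a 1.5-fold lower number (0.17 log units; within the scatter) from compound 2 to compound 4, 2.8-fold (0.45 log units) apart, beyond the scatter of two such steps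

As far as these compounds go, whether a chlorine, a methoxy group or an amine on that same carbon would behave like bromo stays open. So does whether this dependence extends beyond these two cores.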